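From compound 3 to compound 4 in a reporter assay

This account rests on a few compounds, and the source may have more. Where it says the series, first, only, none or still open, it means among the compounds named here.

Compound 1 `CCn1nc(C)cc1C(=O)Nc1nc2cc(C(N)=O)cc(OC)c2n1CCCNC(=O)OCc1ccccc1`: > 100000 nM
Compound 2 `CCCn1c(NC(=O)c2ccnn2C)nc2cc(C(N)=O)cc(OC)c21`: > 100000 nM
Compound 3 `COc1cc(C(N)=O)cc2nc(NC(=O)c3cccnn3)n(CCCNC(=O)OCc3ccccc3)c12`: > 100000 nM

Every entry in an assay for activation of interferon regulatory factor 3 (Homo sapiens), read by a luciferase reporter, with a stated time of 20 h (on this read-out higher numbers stand for an effect only at larger amounts of compound and lower numbers for an effect already at smaller amounts), is a limit rather than a number. Compound 1 reaches only the limit > 100000 nM. Compound 2 reaches only the limit > 100000 nM. Compound 3 likewise stands at the limit > 100000 nM.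

Compound 4 `COc1cc(C(N)=O)cc2nc(NC(=O)c3ccnn3C)n(CCCNC(=O)OCc3ccccc3)c12` differs from compound 3 by 1-methyl-1H-pyrazol-5-yl in place of pyridazin-3-yl on a carbonyl carbon. Among the measured compounds shown here, the one measured step at this position, a step that the two limits leave unreadable from compound 1 to compound 3, cannot be read because of the limit of > 100000 nM in this assay, at which 3 of the 3 values shown sit. Compound 2 carries the same 1-methyl-1H-pyrazol-5-yl group on its carbonyl carbon and also gives only a limit. The step that the limit leaves unreadable from compound 3 to compound 4 is therefore expected to bring nothing beyond the scatter. Compound 4 is expected at 150000 nM, within 40000 nM to 500000 nM, most probably again only a limit.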

Compound 4, half-maximal effective concentration: > 100000 nM
Compound 4 was reported as a limit; the forecaster's own chance of this, stated with the estimate: 85%; the middle value is on the limit's open side.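

In this assay compound 4 gives only a limit, as do compound 1, compound 2 and compound 3, so no step among these four compounds can be read: the limit of > 100000 nM in this assay, at which 4 of the 4 values shown sit.
The compounds shown leave open whether any change at the carbonyl carbon or on the chain gives a measurable effect.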